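Bromo in place of chloro on an aromatic carbon

The source may hold more compounds than are shown below. What is called first, only, known or untested is meant among the compounds shown, and "the series" means these compounds.

compound 1 `Nc1ccccc1NC(=O)CCCNCC(=O)Nc1cccc(Cl)c1`: 75000 nM
compound 2 `Nc1ccccc1NC(=O)CCCNCC(=O)Nc1ccc(Cl)cc1`: 45000 nM
compound 3 `Nc1ccccc1NC(=O)CCCNCC(=O)Nc1ccc(Br)cc1`: not yet measured

In a functional assay on HCT-116 cells (Homo sapiens) for inhibition, read by MTT assay, with a stated time of 2 days (a higher number here means a weaker inhibitor of growth, a lower number a stronger inhibitor of growth), compound 2 gives 45000 nM. For the measured compounds named here, only one other number stands beside it, and the two lie within the usual scatter of each other, so neither can be ranked above the other. Compound 3 differs from compound 2 in one place: bromo in place of chloro on an aromatic carbon. Going by the values given here, the single measured step is a 1.7-fold lower number from compound 1 to compound 2 (0.22 log units; within the scatter). It moved the chloro group to a different place on the ring and kept the group itself, so it bears on the new change only indirectly. Among the compounds with values here, no measured pair swaps chloro for bromo. That one step stayed small, and no step beyond the scatter is expected in this assay, in either direction. The estimated step is a 1.1-fold lower number from compound 2 to compound 3 (0.05 log units; within the scatter). Compound 3 is expected at about 40000 nM (estimated range 20000 nM to 75000 nM).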

Compound 3, concentration for total growth inhibition: 55500 nM
The estimate for compound 3 lay 1.4-fold (0.14 log units) below the measured number, and the stated range covers the measured number.
By their numbers in this assay, from the lowest: compounds 2, 3 and 1 (each within the scatter of the next).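

In this assay, putting bromo in place of chloro on an aromatic carbon, para to a large group, gives a 1.2-fold higher number from compound 2 to compound 3 (0.09 log units; within the scatter) and so produces no readable change. Changing the halogen and its place on the ring together gives a 1.4-fold lower number from compound 1 to compound 3 (0.13 log units; within the scatter) and also stays within the scatter. Compound 1, compound 2 and compound 3 therefore cannot be ranked, and across these three compounds neither the choice between these two halogens nor the difference between the 3-chlorophenyl and 4-bromophenyl groups shifts the number beyond the scatter.

Going by these compounds, it remains open whether a different kind of group at this position, such as an amine or a carboxylic acid, or a longer chain in the shared core, would move the number further. No outside measurement is available to account for these small steps.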